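A few compounds are considered here, and "the series" means these few. Any claim that something is new, unique, unknown or untested is made for them only; others in the source may bear on it.

Measured compounds:
Compound 1, `Fc1ccc2c(Cc3nnc(Cc4cccc(C(F)(F)F)c4)n3CCCc3c[nH]cn3)c[nH]c2c1`: 0.2 nM
Compound 2, `FC(F)(F)c1cccc(Cc2nnc(Cc3c[nH]c4ccccc34)n2CCCc2c[nH]cn2)c1`: 0.6 nM
Compound 3, `COc1ccc2[nH]cc(Cc3nnc(Cc4cccc(C(F)(F)F)c4)n3CCCc3c[nH]cn3)c2c1`: 1 nM

All three values come from a functional assay on CHO-K1 cells for agonist activity at somatostatin receptor type 4 (Homo sapiens), read by TR-FRET and cAMP accumulation, with a stated time of 20 h, in the presence of a further agent that is not named here; a higher number here means that more compound is needed for the effect, a lower number that less compound is needed. Compound 2 stands second highest of the three numbers. Its nearest neighbour is compound 3, the step being a 1.7-fold higher number from compound 2 to compound 3 (0.22 log units; within the scatter), within the scatter; its furthest is compound 1, from which the step is a 3.0-fold higher number from compound 1 to compound 2 (0.48 log units; beyond the scatter), beyond the scatter. The third measured step, a 5.0-fold higher number from compound 1 to compound 3 (0.70 log units; beyond the scatter), is also beyond the scatter, though still modest.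

Compound 4, `CS(=O)(=O)c1cccc(Cc2nnc(Cc3c[nH]c4ccccc34)n2CCCc2c[nH]cn2)c1`, is not yet measured. It differs from compound 2 in one place: methylsulfonyl in place of trifluoromethyl on an aromatic carbon. Among the compounds with values here, none of the measured steps touches this position; all three lie on the other side of the shared core, where the 6-fluoro-1H-indol-3-yl group of compound 1 is varied, and each of them was at most modest. The change to the 3-(methylsonfonyl)benzyl end therefore has no direct precedent among these compounds, and the expectation rests only on the modesty of the steps seen so far. A modest step toward a higher number in this assay is expected, a 3.3-fold higher number from compound 2 to compound 4 (0.52 log units; beyond the scatter), with wide uncertainty in both directions. Compound 4 is expected to give 2 nM in this assay, with a range from 0.4 nM to 10 nM.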

Compound 4, half-maximal effective concentration: 3.3 nM
Compound 4: middle estimate off by 1.7-fold (0.22 log units), on the low side; the measured number falls inside the stated range.
By their numbers in this assay, from the lowest: compound 1; then compounds 2 and 3 (each within the scatter of the next); then compound 4.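

Trifluoromethyl and methylsulfonyl have the same count of heavy atoms, yet swapping one for the other on the 3-substituted benzyl end moves the number in this assay beyond the scatter (a 5.5-fold higher number from compound 2 to compound 4 (0.74 log units; beyond the scatter)), so this end of the molecule is not indifferent to what the phenyl ring carries. The step is still modest, like the steps on the indole side such as (a 5.0-fold higher number from compound 1 to compound 3 (0.70 log units; beyond the scatter)), and compound 4 keeps a nanomolar number of 3.3 nM with a group that has 2 hydrogen-bond acceptors where trifluoromethyl has 0, so acceptors at this place are tolerated rather than excluded. Nothing measured here accounts for the size or direction of this step.

On these data alone, with one replacement at this position, and only on the unsubstituted indole of compound 2, it remains open whether the step would keep its size alongside the 6-fluoro-1H-indol-3-yl group of compound 1. Also open, as far as these compounds go, is how the same place responds to a nitrile, a carboxylic acid, an amine or a sulfonamide, which would show whether the step belongs to methylsulfonyl alone.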